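A few compounds are considered here, and "the series" means these few. Any claim that something is new, unique, unknown or untested is made for them only; others in the source may bear on it.

In an assay for inhibition of epoxide hydrolase 1 (Homo sapiens), read by fluorescence, using microsomes (a higher number here means a weaker inhibitor, a lower number a stronger inhibitor), compound 1 `CC(=O)NC(=S)Nc1ccncc1` gives 2070 nM and compound 2 `O=C(NC(=S)Nc1ccncc1)c1ccccc1` gives 2280 nM; the two differ by methyl in place of phenyl on a carbonyl carbon, and that change made a step of a 1.1-fold lower number from compound 2 to compound 1 (0.04 log units; within the scatter). Compound 3 `COc1cc(C)ccc1NC(=S)NC(=O)c1ccccc1` gives 2540 nM in this assay; the difference between its core and the core of compound 2 is not broken down here, so only their two values can be compared, and these lie within the scatter of each other. Compound 4 `COc1cc(C)ccc1NC(=S)NC(C)=O` carries the same change, (methyl in place of phenyl on a carbonyl carbon), made on the core of compound 3. Because the earlier step of a 1.1-fold lower number from compound 2 to compound 1 (0.04 log units; within the scatter) stayed within the scatter, compound 4 is expected to show a step of a 1.1-fold lower number from compound 3 to compound 4 (0.04 log units; within the scatter) in this assay. Compound 4 is thus estimated at 2300 nM, between 1200 nM and 4500 nM.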

Compound 4, half-maximal inhibitory concentration: 1690 nM
Beside the measured number, compound 4's estimate is 1.4-fold (0.13 log units) above it; the measured number falls inside the stated range.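

In this assay putting methyl in place of phenyl on a carbonyl carbon made a step of a 1.5-fold lower number from compound 3 to compound 4 (0.18 log units; within the scatter), and this step agrees with the earlier one on the other core: the same change on two cores in this assay, a 1.1-fold lower number (0.04 log units; within the scatter) from compound 2 to compound 1 and a 1.5-fold lower number (0.18 log units; within the scatter) from compound 3 to compound 4, 1.4-fold (0.13 log units) apart, within the scatter of two such steps. On these two cores, then, the change carried over with no difference that stands clear of the scatter. Each step itself lies within the scatter, however, so neither shows that the change moves the number at all, and two cores cannot say how it would behave on a third.

The compounds shown leave open whether another group on this carbonyl carbon, such as an amine or a longer alkyl chain, would give a step beyond the scatter.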